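Swapping the aryl ether of compound 1 for an iodophenyl

The source may report more compounds than this note shows. Statements on the series, on what has been measured and on what is new or still open speak of the compounds shown alone.

Measured compounds:
- compound 1, `CCc1nn(C)c(CO/N=C/c2c(C)nn(C)c2Oc2cccc(Cl)c2)c1Cl`, < 80% in a functional assay on SMMC-7721 cells (Homo sapiens) for inhibition, read by MTT assay, with a stated time of 72 h, tested at 25 uM; a higher number here means more inhibition at the concentration tested (going by the name of the read-out), a lower number less inhibition
- compound 2, `Cc1ccc(Oc2c(/C=N\OCc3c(Cl)c(-c4ccc(F)cc4)nn3C)c(C)nn2C)cc1`, 80% in this assay

In this assay compound 1 gives only a limit of the assay, < 80%, not a number. This is the point at which one of the two recorded values sits (the limit of < 80% in this assay, at which 1 of the 2 values shown sits). Compound 2 gives 80% in this assay. The two compounds differ in several places at once, so no single step can be read between them.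

Compound 3, `CCc1nn(C)c(CO/N=C/c2c(C)nn(C)c2Oc2ccc(I)cc2)c1Cl`, is not yet measured. It differs from compound 1 in one place: 4-iodophenyl in place of 3-chlorophenyl on an oxygen on an aromatic ring.

Going by the values given here, no measured step of this kind is known here, so the expected change from compound 1 to compound 3 is small, a step that the limit leaves unreadable from compound 1 to compound 3, in no clear direction beyond the scatter. Compound 3 is expected to give about 50% in this assay, somewhere between 15% and 80%.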

Compound 3, a percentage reported as inhibition, at one concentration (the size of the read-out at that concentration, not a potency): < 80%
Compound 3: no number, only a limit (the forecaster's own chance of this, stated with the estimate: 40%); the middle value does not contradict the limit.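

No step can be read from compound 1 to compound 3, because both give only a limit in this assay, not a number: the limit of < 80% in this assay, at which 2 of the 3 values shown sit. The compounds shown leave open whether 4-iodophenyl in place of 3-chlorophenyl changes the inhibition at all, and in which direction.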